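Replacing a Hydroxy Group with Benzyloxycarbonyl in a Purine Series

A few compounds are considered here, and "the series" means these few. Any claim that something is new, unique, unknown or untested is made for them only; others in the source may bear on it.

Compound 1, with the structure `O=C(CN(c1ncnc2c1ncn2C1CCCCO1)C1CC1)N[C@@H](CO)C(=O)OCc1ccccc1`, was tested in a functional assay on the whole organism (Tail, strain ICR) with Mus musculus as the target, in the tail flick test, with a stated time of 30 min, at a dose of 25 umol/kg by the oral route (a higher number here means a stronger effect of the compound at the dose given, a lower number a weaker effect), where compound 1 gives 27.8%. Among the two compounds measured so far this is the lower number. The other, compound 2 with the structure `O=C(CN(c1nc(Cl)nc2[nH]cnc12)C1CC1)N[C@@H](CO)C(=O)O`, gives 38.7% in this assay, a result that lies above compound 1 by more than the usual scatter of such measurements. Compound 2 differs from compound 1 in more than one place, so the two values only show that compound 2 is the stronger of the pair and say nothing about any single change.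

Compound 3, with the structure `O=C(CN(c1ncnc2c1ncn2C1CCCCO1)C1CC1)N[C@@H](CC(=O)OCc1ccccc1)C(=O)OCc1ccccc1`, has not yet been measured. It differs from compound 1 in one place: benzyloxycarbonyl in place of hydroxy on a saturated chain carbon, two bonds along the chain from an amide-type nitrogen and a carbonyl carbon. Among the compounds with values here, no measured pair shows what this kind of change does, so the expectation rests on compound 1 alone. The step of a number 2.8 percentage points lower from compound 1 to compound 3 (within the scatter) is expected to be small, with no clear direction beyond the scatter. Compound 3 is therefore estimated to give 25%, most likely between 8% and 45%.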

Compound 3, a percentage reported as activity, at one dose (the size of the read-out at that dose, not a potency): 31.8%
For compound 3 the middle estimate is 6.8 percentage points below the measured one; measured number inside the range.
By their numbers in this assay, from the lowest: compounds 1, 3 and 2 (each within the scatter of the next, the first and the last beyond it).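

In this assay, putting benzyloxycarbonyl in place of hydroxy on a saturated chain carbon, two bonds along the chain from an amide-type nitrogen and a carbonyl carbon, gives a number 4 percentage points higher from compound 1 to compound 3 (within the scatter). Within the data shown here, this is the first comparison that isolates one change, and it shows that the read-out at this single dose does not move beyond the scatter when this position goes from hydroxy, with 1 heavy atom, to a group of 10 heavy atoms that carries a six-membered aromatic ring of carbon only and has no hydrogen-bond donor. Nothing measured here explains why such different groups read alike in this test.

The compounds shown leave open how smaller or differently built groups at this place, such as methoxy or a primary amine, would read in this assay. Compound 2 differs from compound 3 in more than one place, so its value cannot be tied to this position.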